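Trimming the Ether Side Chain: Expectations for Compound 4

A few compounds are considered here, and "the series" means these few. Any claim that something is new, unique, unknown or untested is made for them only; others in the source may bear on it.

Measured compounds and their values in a functional assay on CHO cells for antagonist activity at sphingosine 1-phosphate receptor 2 (Homo sapiens), read by calcium flux; a higher number here means a weaker inhibitor, a lower number a stronger inhibitor:
- compound 1 `O=C(O)Cn1nc(Cc2nc3cc(Cl)c(OCC(F)F)cc3[nH]2)c2ccccc2c1=O`: 12 nM
- compound 2 `O=C(O)C1(c2nn(Cc3cn4cc(OCC5CC5)c(Cl)cc4n3)c3ccccc3c2=O)CC1`: 16 nM
- compound 3 `C[C@H](C(=O)O)c1nn(Cc2cn3cc(OCC4CC4)c(Cl)cc3n2)c2ccccc2c1=O`: 3.2 nM

Among these three numbers in this assay, compound 1 holds the second highest. Its nearest neighbour is compound 2, whose value lies within the scatter of repeated measurements, so the two cannot be told apart. For the measured compounds named here, compound 3 sits further off, beyond the scatter, and the only single-point step measured so far leads to it: a 5.0-fold lower number from compound 2 to compound 3 (0.70 log units; beyond the scatter). That step alters the acid-bearing group and says nothing about the ether side chain.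

Compound 4 `COc1cc2[nH]c(Cc3nn(CC(=O)O)c(=O)c4ccccc34)nc2cc1Cl` differs from compound 1 by hydrogen in place of difluoromethyl on a saturated chain carbon bound to an oxygen on an aromatic ring. Going by the values given here, no measured step touches this part of the molecule, so there is no direct guide. With nothing pointing either way, no step beyond the scatter is expected from this change. Compound 4 is therefore estimated at 15 nM, within a range from 5 nM to 45 nM. This estimate means an expected 1.3-fold higher number from compound 1 to compound 4 (0.10 log units; within the scatter), a shift judged to stay within the usual scatter.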

Compound 4, half-maximal inhibitory concentration: 61 nM
Compound 4: the middle estimate sits 4.1-fold (0.61 log units) below what was measured; the measured number lies above the stated range.
By their numbers in this assay, from the lowest: compound 3; then compounds 1 and 2 (each within the scatter of the next); then compound 4.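

In this assay, the ether side chain on the core of compound 1 proves not to be a neutral place. Methoxy in place of 2,2-difluoroethoxy goes with a 5.1-fold higher number from compound 1 to compound 4 (0.71 log units; beyond the scatter), a step beyond the scatter. For the compounds shown here, this is the first measured change at this part of the molecule, and it shows that hydrogen cannot stand in for difluoromethyl here without weaker inhibition. Nothing in the available data explains why the number rises.

This single change removes the carbon and both fluorine atoms together, so the compounds shown cannot separate the effect of losing the fluorine from that of shortening the chain. An ethoxy group, which keeps the 2,2-difluoroethoxy chain length without fluorine, would address that question, while a longer chain on the same oxygen remains an open case.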